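Dropping the Fluorine from a Biaryl Nitrile Series

The source may report more compounds than this note shows. Statements on the series, on what has been measured and on what is new or still open speak of the compounds shown alone.

Compound 1, `CC[C@@H](Nc1c(C#N)c(-c2ccc(-c3cccc(Cl)c3F)cc2)nc2cnccc12)C(N)=O`: 3.1
Compound 2, `CC[C@@H](Nc1c(C#N)c(-c2ccc(-c3cccc(Cl)c3F)cc2)nc2cnccc12)C(=O)O`: 2.2
Compound 3, `CCOc1ccccc1-c1ccc(-c2nc3cnccc3c(NC(C(N)=O)C3CC3)c2C#N)cc1`: 3

In a physicochemical assay for lipophilicity, read by HPLC, at pH 7.5 (a higher number here means a more lipophilic compound, a lower number a more polar compound), compound 1 holds the highest of the three numbers. Compound 3 sits within the scatter of it, so the two cannot be ordered. For the measured compounds named here, compound 2 is the furthest away; the only measured step, a number 0.90 log units lower from compound 1 to compound 2 (beyond the scatter), lies beyond the scatter.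

Compound 4, `CC[C@@H](Nc1c(C#N)c(-c2ccc(-c3ccccc3Cl)cc2)nc2cnccc12)C(N)=O`, differs from compound 1 in one place: 2-chlorophenyl in place of 3-chloro-2-fluorophenyl on an aromatic carbon. Going by the values given here, no measured step touches this position; the single known step concerns hydroxy in place of amino on a carbonyl carbon and so offers no guide here. With nothing to go on beyond the loss of one fluorine, the step from compound 1 is expected to be small, at most a slight drop, likely within the scatter: a number 0.15 log units lower from compound 1 to compound 4 (within the scatter). Compound 4 is therefore estimated at 2.95, between 2.6 and 3.3.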

Compound 4, distribution coefficient: 2.9
For compound 4 the middle estimate is 0.05 log units above the measured one; measured number inside the range.
By their numbers in this assay, from the lowest: compound 2; then compounds 4, 3 and 1 (each within the scatter of the next).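

In this assay this position on an aromatic carbon now has its first reading, a number 0.20 log units lower from compound 1 to compound 4 (within the scatter) when 2-chlorophenyl stands in place of 3-chloro-2-fluorophenyl. For the compounds shown here, the fluorine can thus leave this ring with no change that stands clear of the scatter, whereas the only earlier step concerned a carbonyl carbon.

Still open, from the compounds shown here alone, is how other groups would read on this ring, such as a trifluoromethyl or a methoxy in place of the chlorine. Going by these compounds, whether the hydroxy step on the carbonyl carbon would repeat with 2-chlorophenyl also stays open. No supporting evidence bears on this result.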